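Sulfonyl substituent swap in a hepatocyte clearance series

The source may hold more compounds than are shown below. What is called first, only, known or untested is meant among the compounds shown, and "the series" means these compounds.

The core shared by these compounds carries an amide-linked pyrrolidine bearing a sulfonamide. Compound 1 `Cc1ccc2[nH]c(C(=O)N[C@H]3CN(S(=O)(=O)c4cccnc4)C[C@@H]3C(=O)NCCN(C)C)cc2c1` gives 8 uL/min in an ADME assay on cells (Hepatocyte, Rattus norvegicus) for metabolic stability; a higher number here means faster removal of the compound, a lower number slower removal. Compound 2 `Cc1ccc2[nH]c(C(=O)N[C@H]3CCN(S(=O)(=O)C4CC4)C[C@@H]3C(=O)NCCN(C)C)cc2c1` gives 7 uL/min in this assay, the lowest of the two numbers, though its gap to compound 1 lies within the scatter. Compound 3 `Cc1ccc2[nH]c(C(=O)N[C@H]3CCN(S(=O)(=O)N(C)C)C[C@@H]3C(=O)NCCN(C)C)cc2c1` differs from compound 2 by dimethylamino in place of cyclopropyl on a sulfonyl sulfur. Within the data shown here, since no step between measured compounds is available, compound 3 is expected to show a step of no change at the digits printed from compound 2 to compound 3 (within the scatter) that does not exceed the scatter in either direction. Compound 3 is thus estimated at 7 uL/min, within 3.5 uL/min to 14 uL/min.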

Compound 3, intrinsic clearance in a liver preparation (reported as CLH), per the amount of preparation that the assay uses: 10 uL/min
Beside the measured number, compound 3's estimate is 1.4-fold (0.15 log units) below it; measured number inside the range.
By their numbers in this assay, from the lowest: compounds 2, 1 and 3 (each within the scatter of the next).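

Among these compounds, on the sulfonyl sulfur, dimethylamino in place of cyclopropyl gives a 1.4-fold higher number from compound 2 to compound 3 (0.15 log units; within the scatter) in this assay and so marks the first single-place comparison at this position. With the sulfonamide nitrogen in a ring as its neighbour, the sulfur carries either the carbon-only ring or the open nitrogen-containing group without a step beyond the scatter. Nothing shown bears on why these two compounds read so closely. As far as these compounds go, whether a morpholine or a plain methyl on the sulfonyl sulfur would stay as close to compound 2 remains open. So does whether the same swap would read alike on the core of compound 1.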